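The source may hold more compounds than are shown below. What is called first, only, known or untested is meant among the compounds shown, and "the series" means these compounds.

Measured so far:
Compound 1, `COc1ccc(/C=C2\CCC/C(=C\c3ccc([N+](=O)[O-])cc3)C2=O)cc1OC`: 95000 nM
Compound 2, `O=C1/C(=C/c2ccc(O)cc2)CCC/C1=C\c1ccc([N+](=O)[O-])cc1`: > 400000 nM

Compound 1 and compound 2 share the same core and differ only in the groups on one of the two aromatic rings. In a functional assay on HPLF cells (Homo sapiens) for cytotoxicity (a higher number here means that more compound is tolerated, a lower number that less compound is tolerated), compound 1 gives 95000 nM. For compound 2 this assay reports only a limit, > 400000 nM, so its true value is not known as a number; it sits at the limit of > 400000 nM in this assay, at which 1 of the 2 values shown sits. Compound 2 therefore stands at the most tolerated end of what has been seen here, though only as a bound.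

Compound 3, `COc1ccc(/C=C2\CCC/C(=C\c3ccc([N+](=O)[O-])cc3)C2=O)cc1`, is not yet measured. It differs from compound 2 by methyl in place of hydrogen on an oxygen on an aromatic ring. Given the numbers seen for compound 1 and compound 2, compound 3 is expected to land between them, with a step from the limit of compound 2 of an at least 2.0-fold lower number from compound 2 to compound 3 (0.30 log units; that floor lies within the scatter) downward in this assay or none beyond the scatter. The expected value for compound 3 is 200000 nM, in a range from 70000 nM to 500000 nM.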

Compound 3, half-maximal cytotoxic concentration: > 400000 nM
Compound 3: a limit, no number (the forecaster's own chance of this, stated with the estimate: 35%); middle value at least 2.0-fold (0.30 log units) away from the limit.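

In this assay compound 3 gives > 400000 nM, which is a limit and not a number. Compound 1 and compound 3 differ in one place, and hydrogen in place of methoxy on an aromatic carbon gives an at least 4.2-fold higher number from compound 1 to compound 3 (0.62 log units; beyond the scatter), so that single methoxy separates a measured value from a limit. The step from compound 2 to compound 3, hydroxy to methoxy, cannot be read, and methyl in place of hydrogen on that oxygen does not bring the result down to a measured number: the limit of > 400000 nM in this assay, at which 2 of the 3 values shown sit.

On these data alone, the true values of compound 2 and compound 3 remain unknown, so any difference between them stays hidden. Also open, as far as these compounds go, is what an amine, a carboxylic acid or a longer chain such as ethoxy on this ring would do in this assay.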